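Taking One Chloro Off Compound 3

The compounds below may be only part of what the source reports. "The series", "measured", "known", "first", "only" and "open" are said of these compounds alone.

Of the compounds shown here, three that share one core have been measured in a functional assay, with a stated time of 20 min, tested at 20 uM; on this read-out lower numbers stand for a weaker effect and higher numbers for a stronger effect at the one concentration tested. Compound 1 `COc1cc(/C=C/C(=O)C2=C(/C=C/c3ccc(O)c(OC)c3)NC(=S)NC2c2ccccc2O)ccc1O` gives 79.9%. Compound 2 `COc1cc(/C=C/C(=O)C2=C(/C=C/c3ccc(O)c(OC)c3)NC(=S)NC2c2ccc(N(C)C)cc2)ccc1O` gives 72.1%. Compound 3 `COc1cc(/C=C/C(=O)C2=C(/C=C/c3ccc(O)c(OC)c3)NC(=S)NC2c2c(Cl)cccc2Cl)ccc1O` gives 33.9%, the lowest of the three numbers: the steps of a number 46 percentage points lower from compound 1 to compound 3 (beyond the scatter) and a number 38.2 percentage points lower from compound 2 to compound 3 (beyond the scatter) are both large and beyond the scatter, while a number 7.8 percentage points lower from compound 1 to compound 2 (within the scatter) stays within it. Compound 4 `COc1cc(/C=C/C(=O)C2=C(/C=C/c3ccc(O)c(OC)c3)NC(=S)NC2c2ccccc2Cl)ccc1O` has not yet been measured. It differs from compound 3 in one place: hydrogen in place of chloro on an aromatic carbon. Within the data shown here, both large measured steps concern the arrival of the 2,6-dichlorophenyl group and so bear on this step from the other side; no measured step shows what taking away a single chloro does on its own. Removing one of the two chloro groups is expected to give back part of what was lost, so the estimated step is a number 21.1 percentage points higher from compound 3 to compound 4 (beyond the scatter). Compound 4 is therefore expected to come to about 55%, within a range from 30% to 80%.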

Compound 4, a percentage reported as activity, at one concentration (the size of the read-out at that concentration, not a potency): 39.2%
Beside the measured number, compound 4's estimate is 15.8 percentage points above it, and the stated range covers the measured number.
By their numbers in this assay, from the lowest: compounds 3 and 4 (each within the scatter of the next); then compounds 2 and 1 (each within the scatter of the next).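

With one chloro or two on this phenyl group, the numbers in this assay cannot be told apart: a number 5.3 percentage points higher from compound 3 to compound 4 (within the scatter) is the whole step, so the 2,6-dichlorophenyl and 2-chlorophenyl groups cannot be put in order here. The second chloro is thus not needed for the low numbers, since the 2-chlorophenyl group alone gives two large steps, a number 32.9 percentage points lower from compound 2 to compound 4 (beyond the scatter) and a number 40.7 percentage points lower from compound 1 to compound 4 (beyond the scatter), and compound 3 adds nothing clear to them. The last of these steps is the sharpest comparison, as it exchanges only hydroxy for chloro on one aromatic carbon.

No measured property bears on these results, so the reason for the low numbers with chloro remains unexplained. From the compounds shown here alone, it also remains open whether a fluoro, methyl or methoxy group on that aromatic carbon would give a number closer to compound 1 or to compound 4.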